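Series notes: from compound 3 to compound 4 in cytotoxicity

This account rests on a few compounds, and the source may have more. Where it says the series, first, only, none or still open, it means among the compounds named here.

Measured so far in an ADME assay on Vero cells (Chlorocebus sabaeus) for cytotoxicity, read by neutral red uptake, tested at 1575 ug/mL; on this read-out higher numbers stand for a weaker effect at the one concentration tested and lower numbers for a stronger effect:
compound 1 `O=C1CSC(c2c(Cl)cccc2Cl)N1CCN1CCCCC1`: 10%
compound 2 `COc1ccc(C2SCC(=O)N2CCN2CCCCC2)cc1`: 11%
compound 3 `O=C1CSC(c2cccc(Cl)c2)N1CCN1CCCCC1`: 20%

Compound 3 stands at the top of the three numbers in this assay, yet its gaps to compound 2 and to compound 1 both lie within the usual scatter, so the three compounds are not separable on these readings.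

Compound 4 `O=C1CSC(c2cccc(O)c2)N1CCN1CCCCC1` is the next to be run in this assay. It differs from compound 3 in one place: hydroxy in place of chloro on an aromatic carbon. Going by the values given here, no pair of measured compounds differs in a single place, so no measured step speaks to this change. The step expected is a number 3 percentage points lower from compound 3 to compound 4 (within the scatter), none beyond the scatter. Compound 4 is estimated to give 17%, with a range from 5% to 35%.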

Compound 4, a percentage reported as activity, at one concentration (the size of the read-out at that concentration, not a potency): 13%
Estimate against measurement, compound 4: 4 percentage points above; measured number inside the range.
By their numbers in this assay, from the lowest: compounds 1, 2, 4 and 3 (each within the scatter of the next).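

Going by these compounds alone, the first single-place step, hydroxy in place of chloro on an aromatic carbon meta to a large group, reads in this assay as a number 7 percentage points lower from compound 3 to compound 4 (within the scatter) and so does not separate the two compounds. At this position, a hydrogen-bond donor and acceptor entering with hydroxy thus comes with no change beyond the scatter on this read-out. No evidence at hand bears on the reason for this result.

From the compounds shown here alone, whether an amine or a carboxylic acid on this same aromatic carbon would give a step beyond the scatter stays open. Also open, going by these compounds, is whether hydroxy would read the same on other carbons of the ring.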